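The source may report more compounds than this note shows. Statements on the series, on what has been measured and on what is new or still open speak of the compounds shown alone.

Compound 1 `COc1cccc(-c2ncc(C(=O)O)c(=O)[nH]2)c1` is the starting point; in a functional assay on the whole organism (strain Sprague-Dawley) for inhibition, with Rattus norvegicus as the target, with a stated time of 10 min (a higher number here means that more compound is needed for the effect, a lower number that less compound is needed), compound 1 gives 10 mg/kg. Compound 2 `CCOc1ccc(OC)cc1-c1ncc(C(=O)O)c(=O)[nH]1` carries one change, (ethoxy in place of hydrogen on an aromatic carbon), and in this assay compound 2 gives 0.2 mg/kg, so the step of a 50-fold lower number from compound 1 to compound 2 (1.70 log units; beyond the scatter). Compound 3 `COc1nc(-c2ccccc2)ncc1C(=O)O` has a different core, and how that core differs from the core of compound 1 is not broken down here. In this assay compound 3 reaches only a limit, > 10 mg/kg, which is the limit of > 10 mg/kg in this assay, at which 1 of the 3 values shown sits. Compound 4 `CCOc1ccccc1-c1ncc(C(=O)O)c(OC)n1`, not yet measured, differs from compound 3 by ethoxy in place of hydrogen on an aromatic carbon. This is the same kind of change as that from compound 1 to compound 2, although the place is not the same: in compound 2 the entering group is also para to a methoxy group, which compound 4 lacks. Because the step of a 50-fold lower number from compound 1 to compound 2 (1.70 log units; beyond the scatter) was large, a step in the same direction is expected for compound 4 in this assay, but since compound 3 shows only a limit, the size is uncertain. The estimate for compound 4 is 3 mg/kg, between 0.5 mg/kg and 30 mg/kg. For compound 4 this amounts to an expected step of an at least 3.3-fold lower number from compound 3 to compound 4 (0.52 log units; beyond the scatter).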

Compound 4, dose for 50% inhibition: > 5 mg/kg
Compound 4 ended at the assay's limit; the forecaster's own chance of this, stated with the estimate: 40%; at least 1.6-fold (0.22 log units) between middle value and limit.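

In this assay compound 3 sits at a limit: the limit of > 10 mg/kg in this assay, at which 1 of the 4 values shown sits. Compound 4 also sits at a limit: the limit of > 5 mg/kg in this assay, at which 1 of the 4 values shown sits. Among the compounds shown here, with both values being limits, no step between compound 3 and compound 4 can be read. The compounds shown leave open whether ethoxy in place of hydrogen on an aromatic carbon changes the dose needed on the core of compound 3 at all.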